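The source may hold more compounds than are shown below. What is called first, only, known or untested is meant among the compounds shown, and "the series" means these compounds.

Series notes. In a functional assay on NCI-H1975 cells (Homo sapiens) for inhibition, read by MTT assay, with a stated time of 72 h (on this read-out lower numbers stand for stronger inhibition and higher numbers for weaker inhibition), compound 3 `CCOc1cc2ncnc(Nc3ccc(F)c(Cl)c3)c2cc1OC(=O)CSc1ncc[nH]1` gives 1400 nM, the lowest number of the three measured analogues; compound 1 `CCOc1cc2ncnc(Nc3ccc(F)c(Cl)c3)c2cc1OC(=O)CSc1ncccn1` gives 3600 nM and compound 2 `CCOc1cc2ncnc(Nc3ccc(F)c(Cl)c3)c2cc1OC(=O)CSc1nccn1C` gives 6900 nM. Compound 4 `CCOc1cc2ncnc(Nc3ccc(F)c(Cl)c3)c2cc1OC(=O)CSc1nc2ccccc2n1C` awaits measurement; its change from compound 3 is 1-methyl-1H-benzimidazol-2-yl in place of 1H-imidazol-2-yl on a sulfur. The step bearing most on it is a 4.9-fold lower number from compound 2 to compound 3 (0.69 log units; beyond the scatter), where hydrogen in place of methyl on the aromatic nitrogen lowered the number; compound 4 carries the methyl again. The step of a 2.6-fold lower number from compound 1 to compound 3 (0.41 log units; beyond the scatter) also left the bare ring lowest. Among the measured compounds shown here, the fused six-membered ring has no counterpart among the measured compounds. Relative to compound 3 a higher number is therefore expected. For compound 4 the estimate is 7000 nM, range 2500 nM to 20000 nM, an expected step of a 5.0-fold higher number from compound 3 to compound 4 (0.70 log units; beyond the scatter).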

Compound 4, half-maximal inhibitory concentration: 9100 nM
The estimate for compound 4 lay 1.3-fold (0.11 log units) below the measured number; measured number inside the range.
By their numbers in this assay, from the lowest: compound 3; then compounds 1, 2 and 4 (each within the scatter of the next, the first and the last beyond it).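

On the sulfur, the fused six-membered aromatic ring of carbon only adds nothing readable to the methylated ring: 1-methyl-1H-benzimidazol-2-yl in place of 1-methyl-1H-imidazol-2-yl gives a 1.3-fold higher number from compound 2 to compound 4 (0.12 log units; within the scatter). The lowest number therefore remains with the bare 1H-imidazol-2-yl, as a 6.5-fold higher number from compound 3 to compound 4 (0.81 log units; beyond the scatter) shows, while a 2.5-fold higher number from compound 1 to compound 4 (0.40 log units; beyond the scatter) puts the new group on the higher side of pyrimidin-2-yl as well. Open, from the compounds shown here alone, is whether 1H-benzimidazol-2-yl, without the methyl, would return the number towards that of the bare ring, and how an amine or a carboxylic acid on the fused ring would read. Nothing available explains these steps.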